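The compounds below may be only part of what the source reports. "The series", "measured", "known", "first", "only" and "open" are said of these compounds alone.

In a functional assay on PC-3 cells (Homo sapiens) for inhibition, read by MTT assay, with a stated time of 24 h; on this read-out higher numbers stand for weaker inhibition and lower numbers for stronger inhibition:
Compound 2 `CC(C)(C)/[N+]([O-])=C/c1cn(-c2ccccc2)nn1` gives 15400 nM.
Compound 3 `CC(C)(C)/[N+]([O-])=C/c1cn(-c2ccc(F)cc2)nn1` gives 72100 nM.
Compound 1 `COc1ccc(-n2cc(/C=[N+](\[O-])Cc3ccccc3)nn2)cc1` reaches only a limit of the assay, > 100000 nM.

Compound 3 thus holds the highest of the two numbers in this assay; compound 2 sits at a lower number, and compound 1 contributes a limit rather than a number. The single measured step among these, a 4.7-fold higher number from compound 2 to compound 3 (0.67 log units; beyond the scatter), shows that fluoro in place of hydrogen on the aromatic carbon raised the number beyond the scatter.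

Compound 4 `COc1ccc(-n2cc(/C=[N+](\[O-])C(C)(C)C)nn2)cc1` differs from compound 3 by methoxy in place of fluoro on an aromatic carbon. Among the measured compounds shown here, no measured step covers methoxy in place of fluoro, so the direction of this change is not fixed by the data. For the measured compounds named here, compound 1 carries the same methoxy group but a benzyl group on the nitrone rather than tert-butyl, and its result in this assay is a limit; this is a different pair and no step is counted for it. Compound 4 is therefore expected to land near compound 3, with the step of a 1.2-fold lower number from compound 3 to compound 4 (0.08 log units; within the scatter) estimated to stay within or close to the scatter. Compound 4 is estimated at 60000 nM, between 15000 nM and 200000 nM.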

Compound 4, half-maximal inhibitory concentration: 23800 nM
The estimate for compound 4 lay 2.5-fold (0.40 log units) above the measured number, and the stated range covers the measured number.
By their numbers in this assay, from the lowest: compounds 2 and 4 (each within the scatter of the next); then compound 3. At a limit, above all of these: compound 1.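

In this assay, the position on an aromatic carbon para to a large group had shown only the step for fluoro, and it now shows that the group entering there decides the outcome, since methoxy in place of fluoro gives a 3.0-fold lower number from compound 3 to compound 4 (0.48 log units; beyond the scatter). Methoxy in place of hydrogen gives a 1.5-fold higher number from compound 2 to compound 4 (0.19 log units; within the scatter), so among these three compounds only fluoro separates from hydrogen beyond the scatter, and the raised number seen with fluoro does not extend to methoxy. The change at the other end of the molecule can now also be read, as tert-butyl in place of benzyl on the double-bonded nitrogen gives an at least 4.2-fold lower number from compound 1 to compound 4 (0.62 log units; beyond the scatter), a step that starts from a limit and not from a number: the limit of > 100000 nM in this assay, at which 1 of the 4 values shown sits.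

The compounds shown carry only hydrogen, fluoro or methoxy at this position, so it remains open whether an amine or a carboxylic acid there would follow fluoro or methoxy. On these data alone, it also remains open whether the step from benzyl to tert-butyl would hold with hydrogen or fluoro on the aromatic ring, or how a longer chain would compare on the double-bonded nitrogen.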